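The compounds below may be only part of what the source reports. "The series", "measured", "known", "first", "only" and "open" are said of these compounds alone.

Of the compounds shown here, two from this series have been measured in a functional assay on ZR-75-1 cells (Homo sapiens) for cytotoxicity, read by sulforhodamine B assay, with a stated time of 72 h; on this read-out higher numbers stand for an effect only at larger amounts of compound and lower numbers for an effect already at smaller amounts. Compound 1, with the structure `CCc1cccc2c(OC)c(-c3occ(C)c3C(=O)OC)ccc12`, gives 1.3 ug/mL in this assay. Compound 2, with the structure `CCc1cccc2c(O)c(-c3occ(C)c3C(=O)O)ccc12`, gives 0.3 ug/mL in this assay. For the measured compounds named here, compound 2 therefore has the lowest of the two numbers seen so far, and its nearest neighbour on this scale, compound 1, sits at a number that is higher by a margin beyond the usual scatter of the measurement; no single structural step links these two compounds, so their values can only be set side by side.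

The next compound, compound 3, has the structure `COc1cccc2c(O)c(-c3occ(C)c3C(=O)O)ccc12` and has not yet been measured in this assay. It differs from compound 2 in one place: methoxy in place of ethyl on an aromatic carbon. Since the group that leaves and the group that enters are both small and of the same heavy-atom count, the step of a 1.7-fold higher number from compound 2 to compound 3 (0.22 log units; within the scatter) is expected to stay within or close to the scatter. Compound 3 is thus expected to give about 0.5 ug/mL in this assay, with a likely range from 0.2 ug/mL to 1.5 ug/mL.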

Compound 3, concentration for half-maximal effect: 0.6 ug/mL
For compound 3 the middle estimate is 1.2-fold (0.08 log units) below the measured one; the range from low to high includes it.
By their numbers in this assay, from the lowest: compounds 2 and 3 (each within the scatter of the next); then compound 1.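

In this assay, putting methoxy in place of ethyl on this aromatic carbon gives a 2.0-fold higher number from compound 2 to compound 3 (0.30 log units; within the scatter), so this read-out does not separate the two compounds. For the compounds shown here, this is the first direct look at this position, which compound 1 and compound 2 could not give, as they are not linked by a single change: here a group with one hydrogen-bond acceptor replaces a group with none at the same heavy-atom count, and the step stays within the scatter. Nothing available on these compounds accounts for this result, so it stands as an observation only.

On these data alone, whether this position accepts other groups remains open, since only ethyl and methoxy are compared there, and an amine, a chlorine atom or a longer chain such as butyl could give a quite different number. Also open, as far as these compounds go, is how the gap between compound 1 and compound 2 divides between their two differences, the methoxy against the hydroxyl on the ring and the methyl ester against the carboxylic acid on the other ring.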